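Swapping the small side chain on the fused core of compound 2

This account rests on a few compounds, and the source may have more. Where it says the series, first, only, none or still open, it means among the compounds named here.

In an ADME assay on a cell-free system (plasma, Homo sapiens) for protein binding, compound 1 `Cc1cc(Nc2ccc(C(F)(F)F)cc2)n2nc(C3CC3)nc2n1` gives 92.8%. Compound 2 `CSc1nc2nc(C)cc(Nc3ccc(C(F)(F)F)cc3)n2n1` gives 91.8% in this assay, and the two values lie within the scatter of each other, as a 1.1-fold higher unbound fraction from compound 1 to compound 2 (0.06 log units; within the scatter) shows. Compound 2 therefore stands together with compound 1 as one of two measured points, without a difference between them that the data support.

Compound 3 `COCCc1nc2nc(C)cc(Nc3ccc(C(F)(F)F)cc3)n2n1` differs from compound 2 in one place: 2-methoxyethyl in place of methylsulfanyl on an aromatic carbon. Among the measured compounds shown here, the only measured step at that position, the one from compound 1 to compound 2, exchanged one small group for another and moved the read-out by no more than the scatter. The change to compound 3 is of a different kind, a longer chain in place of a small group, so that step is only a loose guide. He expects for compound 3 a step of a 1.5-fold higher unbound fraction from compound 2 to compound 3 (0.17 log units; within the scatter), toward a somewhat lower bound fraction, but with the real chance that it stays within the scatter. His estimate for compound 3 in this assay is 88%, with a range from 80% to 94%.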

Compound 3, plasma protein binding: 73.7%
Compound 3: the middle estimate sits 2.2-fold (0.34 log units) (unbound fraction) below what was measured; the whole stated range lies above it.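

At this position on the five-membered aromatic ring, this assay does respond to the group: the exchange of cyclopropyl for methylsulfanyl stayed within the scatter, but 2-methoxyethyl in place of methylsulfanyl gives a 3.2-fold higher unbound fraction from compound 2 to compound 3 (0.51 log units; beyond the scatter), and 2-methoxyethyl in place of cyclopropyl gives a 3.7-fold higher unbound fraction from compound 1 to compound 3 (0.56 log units; beyond the scatter). The two smaller groups therefore cannot be told apart in these data, while the 2-methoxyethyl chain of compound 3 stands apart from both, with the highest unbound fraction of the three. Nothing shown here accounts for the size of these steps.

The compounds shown leave open whether the length of the chain or its oxygen goes with the step, since compound 3 changes both at once, and a butyl chain of carbon alone or a 2-hydroxyethyl group at the same place would begin to separate the two. They also leave open whether an amine or a carboxylic acid at the end of such a chain would shift the bound fraction further, and whether the step holds on any core other than the one shared here.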